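Rearranging the amide substituent of the weakest analogue

The source may hold more compounds than are shown below. What is called first, only, known or untested is meant among the compounds shown, and "the series" means these compounds.

Compound 3 `CCN(Cc1ccccc1)C(=O)c1nn(-c2ccc(F)cc2)c(OC[C@@H](O)C[C@@H](O)CC(=O)O)c1C(C)C` stands at the high end of the three numbers seen so far: in an assay on microsomes from liver for inhibition of 3-hydroxy-3-methylglutaryl-coenzyme A reductase (Rattus norvegicus) (on this read-out lower numbers stand for stronger inhibition and higher numbers for weaker inhibition), compound 3 gives 14 nM. Compound 1 `Cc1ccc(CNC(=O)c2nn(-c3ccc(F)cc3)c(CC[C@@H](O)C[C@@H](O)CC(=O)O)c2C(C)C)cc1` gives 2.5 nM in this assay, and compound 2 `CC(C)c1c(C(=O)N2CCC[C@H](c3ccccc3)C2)nn(-c2ccc(F)cc2)c1CC[C@@H](O)C[C@@H](O)CC(=O)O` gives 2.1 nM, so both sit beyond the scatter below compound 3. Compound 4 `Cc1ccc(CN(C)C(=O)c2nn(-c3ccc(F)cc3)c(OC[C@@H](O)C[C@@H](O)CC(=O)O)c2C(C)C)cc1` has the same atoms as compound 3, joined differently: methyl(4-methylbenzyl)amino in place of benzyl(ethyl)amino on a carbonyl carbon. For the measured compounds named here, the only measured step that alters the group on that same carbonyl carbon is a 1.2-fold lower number from compound 1 to compound 2 (0.08 log units; within the scatter), a swap between two quite different amine partners that left the number essentially where it was; compounds 1 and 2, however, differ from compounds 3 and 4 elsewhere in the molecule, as their structures show, so the comparison is indirect. With that one step within the scatter, a step of similar smallness is expected here, a 1.2-fold lower number from compound 3 to compound 4 (0.07 log units; within the scatter). Compound 4 is therefore estimated at 12 nM, with a range from 5 nM to 30 nM.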

Compound 4, half-maximal inhibitory concentration: 37 nM
Compound 4: middle estimate off by 3.1-fold (0.49 log units), on the low side; measured number above the stated range.
By their numbers in this assay, from the lowest: compounds 2 and 1 (each within the scatter of the next); then compound 3; then compound 4.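

In this assay, the step of a 2.6-fold higher number from compound 3 to compound 4 (0.42 log units; beyond the scatter) is beyond the scatter, although benzyl(ethyl)amino and methyl(4-methylbenzyl)amino have the same heavy-atom count, the same single aromatic ring, and the same counts of donors and acceptors. For the compounds shown here, this group on the carbonyl carbon can therefore shift the number through the arrangement of its atoms alone, whereas the only earlier step there, a 1.2-fold lower number from compound 1 to compound 2 (0.08 log units; within the scatter), stayed within the scatter on a different background. Nothing shown here explains the rise.

On these data alone, two things changed at once, so it remains open whether the ring methyl or the shorter chain on nitrogen matters more; benzyl(methyl)amino and ethyl(4-methylbenzyl)amino would separate the two. As far as these compounds go, it also remains open whether the same swap would have a similar effect on the core of compound 1.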